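The source may hold more compounds than are shown below. What is called first, only, known or untested is meant among the compounds shown, and "the series" means these compounds.

In a functional assay on DU-145 cells (Homo sapiens) for cytotoxicity, read by XTT assay, with a stated time of 24 h (on this read-out higher numbers stand for weaker inhibition and lower numbers for stronger inhibition), the two measured compounds gave these values:

Compound 1 `Cc1cc(Cl)c2c(c1O)C(=O)C=CC2=O`: 9300 nM
Compound 2 `CC(=O)Oc1cc(OC(C)=O)c2c(OC(C)=O)cc(C)c(Cl)c2c1OC(C)=O`: 59600 nM

Compound 1 has the lower of the two numbers, meaning the stronger inhibition; the number of compound 2 lies well beyond the usual scatter above it. The two structures differ in many places at once, so the gap between them cannot be tied to any one change, and nothing more can be drawn from the pair.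

Compound 3 `CCOc1c(C)cc(Cl)c2c1C(=O)C=CC2=O` has not yet been tested in this assay. It differs from compound 1 in a single place: ethyl in place of hydrogen on an oxygen on an aromatic ring. The hydroxy group of compound 1 thus becomes an ethoxy group in compound 3, and the rest of the shared core is kept.

Within the data shown here, no measured pair in this set shows what such a change does here, so the expectation rests on the single value of compound 1. A small step is expected in this assay, toward a somewhat higher number, close to the edge of the scatter. Compound 3 is therefore estimated at 16000 nM, within a range of 5000 nM to 50000 nM, which amounts to an expected step of a 1.7-fold higher number from compound 1 to compound 3 (0.24 log units; within the scatter).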

Compound 3, half-maximal inhibitory concentration: 26200 nM
Beside the measured number, compound 3's estimate is 1.6-fold (0.21 log units) below it, within the range that was stated.
By their numbers in this assay, from the lowest: compound 1; then compound 3; then compound 2.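

Ethyl in place of hydrogen on this oxygen gives the first comparison here that changes only one place: in this assay the switch from hydroxy to ethoxy brings a 2.8-fold higher number from compound 1 to compound 3 (0.45 log units; beyond the scatter) and so lies beyond the usual scatter, although the step is modest. This shows that the change at this position does register in the read-out, with inhibition weaker once the hydrogen is replaced, while compound 3 still gives a measurable value of 26200 nM in the same test. No measurement of any property of these compounds accompanies the result, so the step remains an observation without an explanation.

A single step cannot show whether the loss of the hydrogen itself or the arrival of the ethyl chain matters more, and a methoxy group or a longer chain such as propoxy on the same oxygen would help separate the two. From the compounds shown here alone, it also remains open how this assay would respond to a chain on this oxygen ending in an amine or a carboxylic acid, and whether any replacement here could match or improve on the free hydroxy group.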